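Amide aryl variation on the shared core: compound 3

The compounds below may be only part of what the source reports. "The series", "measured", "known", "first", "only" and "open" are said of these compounds alone.

In a functional assay on HepG2 cells (Homo sapiens) for antiproliferative activity, read by CCK-8 assay, with a stated time of 72 h (on this read-out lower numbers stand for stronger inhibition and higher numbers for weaker inhibition), compound 2 `O=C(Nc1cccc(-c2oc3cc(-c4ccc(F)cc4)ccc3c(=O)c2O)c1)c1ccc(F)cc1` gives 9280 nM. Compound 1 `O=C(Nc1cccc(-c2oc3cc(-c4ccc(F)cc4)ccc3c(=O)c2O)c1)c1ccccc1F` gives 10100 nM in this assay; the step of a 1.1-fold lower number from compound 1 to compound 2 (0.04 log units; within the scatter) is within the scatter, so the two numbers stand together and neither compound can be set apart. Compound 3 `COc1ccc(C(=O)Nc2cccc(-c3oc4cc(-c5ccc(F)cc5)ccc4c(=O)c3O)c2)c(F)c1` carries the change (2-fluoro-4-methoxyphenyl in place of 4-fluorophenyl on a carbonyl carbon). Among the measured compounds shown here, no measured step bears on it directly: the only step exchanges 4-fluorophenyl for 2-fluorophenyl on the carbonyl carbon and stays within the scatter, and no measured compound carries a methoxy group on this ring. For the measured compounds named here, with the shared core unchanged and the single comparison flat, no movement beyond the scatter is expected for compound 3, and the step of a 1.0-fold lower number from compound 2 to compound 3 (0.01 log units; within the scatter) is estimated to be small in this assay. Compound 3 is therefore expected near 9000 nM, with a range from 3500 nM to 25000 nM in this assay.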

Compound 3, half-maximal inhibitory concentration: 45300 nM
Compound 3: the middle estimate sits 5.0-fold (0.70 log units) below what was measured; the measured number lies above the stated range.
By their numbers in this assay, from the lowest: compounds 2 and 1 (each within the scatter of the next); then compound 3.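

The aryl group on the amide carbonyl carbon is not silent in this assay, as the two fluorophenyl compounds alone suggested: the step of a 4.9-fold higher number from compound 2 to compound 3 (0.69 log units; beyond the scatter) lies beyond the scatter, so this position does respond to a change of substituent. With the 2-fluorophenyl group kept, methoxy in place of hydrogen on an aromatic carbon gives the step of a 4.5-fold higher number from compound 1 to compound 3 (0.65 log units; beyond the scatter), which ties the weaker inhibition in this pair to the added methoxy group, and compound 3 has the highest number of the three. No measurement shown here accounts for this change.

Whether this loss is particular to methoxy remains open, since the compounds shown include no hydroxy, amine or carboxylic acid on this ring. Also open, from the compounds shown here alone, is whether a longer ether chain, such as ethoxy, would go further in the same direction.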